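This account rests on a few compounds, and the source may have more. Where it says the series, first, only, none or still open, it means among the compounds named here.

- compound 1 `CCCn1c(=O)n(CCOCC)c(=O)c2[nH]cnc21`: 70 nM
- compound 2 `CCCn1c(=O)n(C)c(=O)c2c1ncn2CCC(=O)O`: > 100000 nM

Both compounds were tested in a functional assay (trachea) with Cavia porcellus as the target; a lower number here means that less compound is needed, a higher number that more compound is needed for the effect. Compound 1 gives a real number there, 70 nM. Compound 2 gives only a limit of the assay, > 100000 nM, not a number.

Compound 3 `CCCn1c(=O)n(C)c(=O)c2c1ncn2CCCO` differs from compound 2 in one place: hydroxymethyl in place of carboxy on a saturated chain carbon, two bonds along the chain from an aromatic nitrogen. Hydroxymethyl stands in place of carboxy on a saturated chain carbon, two bonds along the chain from an aromatic nitrogen, so 2-carboxyethyl becomes 3-hydroxypropyl.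

Going by the values given here, no measured step shows what this change does, so any forecast is uncertain. A move to a lower number in this assay, beyond the scatter, is expected, but only a moderate one. Compound 1, at 70 nM, shows that low numbers are possible with the shared core, although its side chains also differ.

The expected step is an at least 3.3-fold lower number from compound 2 to compound 3 (0.52 log units; beyond the scatter).

For compound 3 the estimated value is 30000 nM, with an expected range of 6000 nM to 100000 nM.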

Compound 3, half-maximal effective concentration: 22600 nM
The estimate for compound 3 lay 1.3-fold (0.12 log units) above the measured number; the range from low to high includes it.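

In this assay, turning 2-carboxyethyl into 3-hydroxypropyl gives an at least 4.4-fold lower number from compound 2 to compound 3 (0.64 log units; beyond the scatter), so a change at this place on the chain can move the result beyond the scatter. Compound 3, at 22600 nM, also gives this chain a real number as a starting point for later comparisons. The step is a minimum rather than an exact size, since it rests on a limit of the assay: the limit of > 100000 nM in this assay, at which 1 of the 3 values shown sits.

From the compounds shown here alone, what an amine, a methyl ester or a longer chain ending in hydroxyl would do at this place remains open. Compound 1 differs from compound 3 in more than one place, so these compounds cannot show how much this chain alone contributes to the distance between their values.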